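Working notes on the alkyl arm: three measured, one pending

The source may hold more compounds than are shown below. What is called first, only, known or untested is meant among the compounds shown, and "the series" means these compounds.

Compound 1, `CCC(C)(C)/N=c1\c(O)c(O)\c1=N/Cc1c(Cl)cccc1Cl`, gives 280 nM in a functional assay for inhibition, with Rattus norvegicus as the target; a lower number here means a stronger inhibitor, a higher number a weaker inhibitor.
Compound 2, `CC(C)(C)/N=c1\c(O)c(O)\c1=N/Cc1c(Cl)cccc1Cl`, gives 1100 nM.
Compound 3, `CC[C@@H](C)/N=c1\c(O)c(O)\c1=N/Cc1ccc(C#N)cc1`, gives 4000 nM.

Compound 1 and compound 2 differ in one place: hydrogen in place of methyl on a saturated chain carbon, two bonds along the chain from a double-bonded nitrogen. That step costs potency, a 3.9-fold higher number from compound 1 to compound 2 (0.59 log units; beyond the scatter). Compound 3 carries a different core from compound 1; how the two cores differ is not broken down here, and of that pair only the two values can be compared, which put compound 3 at the weak end of the three.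

Compound 4, `CCC/N=c1\c(O)c(O)\c1=N/Cc1ccc(C#N)cc1`, has not yet been measured. It differs from compound 3 in one place: hydrogen in place of methyl on a saturated chain carbon bound to a double-bonded nitrogen and a saturated chain carbon. Among the measured compounds shown here, this is the same kind of change as the one from compound 1 to compound 2, but the surroundings differ: in the measured pair the methyl left a saturated chain carbon two bonds along the chain from a double-bonded nitrogen, whereas here it leaves a saturated chain carbon bound to a double-bonded nitrogen and a saturated chain carbon. On one precedent only, the expectation is that removing the methyl again weakens inhibition by a comparable margin, so for compound 4 the expected step is a 2.5-fold higher number from compound 3 to compound 4 (0.40 log units; beyond the scatter), resting on the measured loss a 3.9-fold higher number from compound 1 to compound 2 (0.59 log units; beyond the scatter). Compound 4 is thus estimated at 10000 nM, with a plausible range from 4000 nM to 25000 nM, and a real chance that the assay only returns a limit.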

Compound 4, half-maximal inhibitory concentration: 21900 nM
For compound 4 the middle estimate is 2.2-fold (0.34 log units) below the measured one, and the stated range covers the measured number.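

In this assay the sec-butyl to propyl change gives a 5.5-fold higher number from compound 3 to compound 4 (0.74 log units; beyond the scatter), so removing this methyl also costs potency on the second core. The size of the loss does not separate the two cores: the same change on two cores in this assay, a 3.9-fold higher number (0.59 log units; beyond the scatter) from compound 1 to compound 2 and a 5.5-fold higher number (0.74 log units; beyond the scatter) from compound 3 to compound 4, 1.4-fold (0.14 log units) apart, within the scatter of two such steps. This supports carrying the change between these two cores with a similar loss, but it rests on two pairs only, and the methyl leaves a different place in each, a saturated chain carbon two bonds along the chain from a double-bonded nitrogen in one and a saturated chain carbon bound to a double-bonded nitrogen and a saturated chain carbon in the other, so it neither gives a rule for other cores nor separates the effect of the core from that of the place.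

The compounds shown leave open how far the trend runs along the alkyl arm, for instance whether a longer chain such as pentyl or a ring such as cyclopropyl would keep or lose potency on either core. They also leave open how a hydroxyl group, an amine or a carboxylic acid at the end of that arm would compare with the plain alkyl groups.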